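An Amide Substituent Exchange on a Shared Core

The source may report more compounds than this note shows. Statements on the series, on what has been measured and on what is new or still open speak of the compounds shown alone.

Compound 1 `CC(C)N(C(=O)C1CCN(C(=O)c2ccc(S(C)(=O)=O)c([N+](=O)[O-])c2)CC1)C(C)C` was tested in an assay on isolated protein for inhibition of vitamin D3 receptor (Homo sapiens), read by fluorescence polarization; a lower number here means a stronger inhibitor, a higher number a weaker inhibitor. In this assay compound 1 gives only a limit, > 60000 nM, and no number. Compound 2 `CN(Cc1ccccc1F)C(=O)CNC(=O)c1ccc(S(C)(=O)=O)c([N+](=O)[O-])c1` also yields only a limit in this assay, > 60000 nM. Compound 3 `CN(CC(=O)N(Cc1ccccc1)Cc1ccccc1)C(=O)c1ccc(S(C)(=O)=O)c([N+](=O)[O-])c1` likewise reaches only a limit in this assay, > 60000 nM. Compound 1 thus stands where the other two stand, at the limit of > 60000 nM in this assay, at which 3 of the 3 values shown sit. Compound 4 `CN(Cc1ccccc1)C(=O)C1CCN(C(=O)c2ccc(S(C)(=O)=O)c([N+](=O)[O-])c2)CC1` differs from compound 1 by benzyl(methyl)amino in place of diisopropylamino on a carbonyl carbon. Among the compounds with values here, the measured compounds offer no pair differing in one place, so they give no size of change to lean on. Compound 4 is expected to stay at the limit, with an estimated step that the limit leaves unreadable from compound 1 to compound 4 amounting to no change beyond the scatter. The estimate for compound 4 in this assay is 90000 nM, within 20000 nM to 400000 nM.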

Compound 4, half-maximal inhibitory concentration: > 60000 nM
Compound 4 ended at the assay's limit (the forecaster's own chance of this, stated with the estimate: 85%); the middle value is on the limit's open side.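

Within the data shown here, compound 1 and compound 4 each give only a limit in this assay, and no step between them can be read. The compounds shown leave open which change on the shared core, if any, would yield a measurable value in this assay.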